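Methyl on selenium: from compound 2 to compound 4

The source may hold more compounds than are shown below. What is called first, only, known or untested is meant among the compounds shown, and "the series" means these compounds.

Measured compounds:
compound 1, `COc1ccc(CNc2nc([Se]C)nc3ccccc23)cc1`: > 100000 nM
compound 2, `Nc1nc([SeH])nc2ncccc12`: 31100 nM
compound 3, `[SeH]c1nc([SeH])c2cccnc2n1`: 8260 nM

In an ADME assay on 184B5 cells (Homo sapiens) for cytotoxicity, read by MTT assay, with a stated time of 72 h (on this read-out lower numbers stand for stronger inhibition of growth and higher numbers for weaker inhibition of growth), compound 2 gives 31100 nM. Compound 1 gives > 100000 nM in this assay, which is a limit rather than a number. Of the two numbers present, compound 2 has the higher one; its nearest neighbour is compound 3, and the step of a 3.8-fold lower number from compound 2 to compound 3 (0.58 log units; beyond the scatter) separates the two. Within the data shown here, that step is the only measured step, and it concerns the replacement of one nitrogen by selenium on an aromatic carbon, a different change from the one now followed.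

Compound 4, `C[Se]c1nc(N)c2cccnc2n1`, differs from compound 2 in a single place: methyl in place of hydrogen on a selenium. Among the measured compounds shown here, no measured pair shows this exact change. For the measured compounds named here, the only other compound carrying a methyl on selenium, compound 1, sits at the limit of > 100000 nM in this assay, at which 1 of the 3 values shown sits, so it gives no number to weigh. Compound 4 is therefore expected to remain near compound 2, with a step of a 1.3-fold higher number from compound 2 to compound 4 (0.11 log units; within the scatter) that is not expected to exceed the scatter, though a shift toward higher numbers cannot be excluded. The estimate for compound 4 in this assay is 40000 nM, in a range from 10000 nM to 150000 nM.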

Compound 4, concentration for total growth inhibition: 87200 nM
Beside the measured number, compound 4's estimate is 2.2-fold (0.34 log units) below it; the measured number falls inside the stated range.
By their numbers in this assay, from the lowest: compound 3; then compound 2; then compound 4. At a limit, above all of these: compound 1.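

In this assay, among these compounds, the change at this position gives a 2.8-fold higher number from compound 2 to compound 4 (0.45 log units; beyond the scatter), the only measured reading of methyl in place of hydrogen on a selenium, and it shows that growth inhibition weakens modestly when this hydrogen is replaced. Among the compounds shown here, the one earlier step, a 3.8-fold lower number from compound 2 to compound 3 (0.58 log units; beyond the scatter), concerned a different change at a different place and ran toward lower numbers, so the selenium hydrogen itself is now seen to be a place where a small change moves the number beyond the scatter. Compound 1, the only other compound with a methyl on selenium, stands at a limit, not a number, and differs in more than this one place, so it adds no second reading of the change: the limit of > 100000 nM in this assay, at which 1 of the 4 values shown sits.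

What the compounds shown leave open is whether the shift follows from the loss of the hydrogen or from the methyl that enters, which an ethyl group or a longer chain on the same selenium would help to separate. Going by these compounds, it also remains open whether a carboxylic acid at the end of such a chain would move the number back toward that of compound 2, and whether the same methyl change would give a similar step on the second selenium-bearing compound, compound 3.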